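Ring nitrogen swap on the amide acyl group

The source may report more compounds than this note shows. Statements on the series, on what has been measured and on what is new or still open speak of the compounds shown alone.

Measured compounds:
compound 1 `O=C(NCc1ccc(S(=O)(=O)c2ccccc2)cc1)c1ccc2nccn2c1` gives 18%
compound 2 `O=C(NCc1ccc(S(=O)(=O)c2cccc(C(F)(F)F)c2)cc1)c1ccc2nccn2c1` gives 17%

In an ADME assay on microsomes from liver (Mus musculus) for metabolic stability, read by LC-MS, with a stated time of 30 min, tested at 1 uM (on this read-out higher numbers stand for a more stable compound and lower numbers for a less stable compound), compound 1 gives 18%, and compound 2 gives 17%; the two numbers lie within the scatter of each other, as the step of a number 1 percentage points lower from compound 1 to compound 2 (within the scatter) shows. For the measured compounds named here, compound 1 therefore stands at a number indistinguishable from the only other measured compound.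

Compound 3 `O=C(NCc1ccc(S(=O)(=O)c2ccccc2)cc1)c1cnc2nccn2c1` differs from compound 1 in one place: a group of 9 heavy atoms (6 carbon, 3 nitrogen; one five-membered aromatic ring with 2 hetero atoms, one six-membered aromatic ring with 2 hetero atoms) in place of a group of 9 heavy atoms (7 carbon, 2 nitrogen; one five-membered aromatic ring with 2 hetero atoms, one six-membered aromatic ring with 1 hetero atom), on a carbonyl carbon

Going by the values given here, no measured step touches this part of the molecule; the only measured step, a number 1 percentage points lower from compound 1 to compound 2 (within the scatter), concerns the trifluoromethyl on the sulfonyl-bearing ring and was within the scatter. There is thus no measured basis for a step in either direction, and the expected step in this assay is none beyond the scatter, with a wide range. Compound 3 is estimated at 20%, between 8% and 40%, an expected step of a number 2 percentage points higher from compound 1 to compound 3 (within the scatter).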

Compound 3, percent of the compound remaining: 30%
Beside the measured number, compound 3's estimate is 10 percentage points below it, and the stated range covers the measured number.
By their numbers in this assay, from the lowest: compounds 2 and 1 (each within the scatter of the next); then compound 3.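

In this assay, the group on the carbonyl carbon proved to be a place where a single change moves the read-out: a six-membered aromatic ring with 2 hetero atoms in place of one with 1 hetero atom gave a number 12 percentage points higher from compound 1 to compound 3 (beyond the scatter). This is the first step beyond the scatter among these compounds, whereas the trifluoromethyl change elsewhere in the molecule gave only a number 1 percentage points lower from compound 1 to compound 2 (within the scatter), and here the heavy-atom count of the group stayed the same while one ring carbon gave way to a nitrogen. Nothing measured here bears on why the number rose.

The compounds shown leave open whether the same ring change would give a similar step with the trifluoromethyl group of compound 2 present. They also leave open how a fluorine, a methoxy group or an amine on this acyl group would register in this assay.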